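Swapping a Small Ring for a Fluorophenyl Ring

The source may report more compounds than this note shows. Statements on the series, on what has been measured and on what is new or still open speak of the compounds shown alone.

Measured compounds:
compound 1, `COc1ccc(CNC(=O)c2cc(-c3cncc(C)c3)ncc2-c2cnccn2)nc1OC`: 7.6 nM
compound 2, `COc1ccc(CNC(=O)c2cc(-c3cncc(C)c3)ncc2N2CCC2)nc1OC`: 10 nM

In an assay on CHO cells for displacement of a labelled ligand from Orexin receptor type 2 (Homo sapiens), read by scintillation counting, with a stated time of 3 h (a higher number here means a weaker inhibitor, a lower number a stronger inhibitor), compound 1 gives 7.6 nM and compound 2 gives 10 nM. Compound 2 therefore stands at the higher of the two numbers, but only by a 1.3-fold higher number from compound 1 to compound 2 (0.12 log units; within the scatter), which is within the scatter, so the two cannot be ranked against each other.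

Compound 3, `COc1ccc(CNC(=O)c2cc(-c3cncc(C)c3)ncc2-c2ccccc2F)nc1OC`, has not been measured. It differs from compound 2 by 2-fluorophenyl in place of azetidin-1-yl on an aromatic carbon. Among the compounds with values here, the only step that bears on this position is a 1.3-fold higher number from compound 1 to compound 2 (0.12 log units; within the scatter), where an aromatic pyrazin-2-yl was exchanged for the four-membered azetidin-1-yl without a change beyond the scatter. Compound 3 returns an aromatic six-membered ring to this position, so a step no larger than the scatter is expected in this assay, in either direction. The estimated step of a 1.3-fold lower number from compound 2 to compound 3 (0.10 log units; within the scatter) is expected to be small. Compound 3 is estimated at 8 nM, with a range from 3 nM to 25 nM.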

Compound 3, inhibition constant: 1.4 nM
The estimate for compound 3 lay 5.7-fold (0.76 log units) above the measured number; measured number outside the range, below it.
By their numbers in this assay, from the lowest: compound 3; then compounds 1 and 2 (each within the scatter of the next).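

Compound 3 shows that this position is not indifferent to the group it carries: the exchange of pyrazin-2-yl for azetidin-1-yl had moved nothing beyond the scatter, whereas 2-fluorophenyl gives a 7.1-fold lower number from compound 2 to compound 3 (0.85 log units; beyond the scatter) and a 5.4-fold lower number from compound 1 to compound 3 (0.73 log units; beyond the scatter) in this assay and so has the lowest number of the three. An aromatic six-membered ring at this position is not enough for that number, since compound 1 also carries one, in the form of pyrazin-2-yl. No measurement at hand explains the difference.

From the compounds shown here alone, whether the step rests on the fluorine or on the carbon-only ring stays open, and a plain phenyl group would separate the two. How a chlorine or a methoxy group would serve in place of the fluorine is also unknown.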